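Hydroxycarbamoyl chain length on two cores

The source may report more compounds than this note shows. Statements on the series, on what has been measured and on what is new or still open speak of the compounds shown alone.

Measured compounds:
compound 1 `CC(C)CCc1c(OCCCCCCCC(=O)NO)ccc2ccc(=O)oc12` — 2190 nM
compound 2 `CC(C)CCc1c(OCCCCC(=O)NO)ccc2ccc(=O)oc12` — 2760 nM
compound 3 `CC(C)CCc1c(OCCCCC(=O)NO)ccc2c1OC(=O)CC2` — > 30000 nM

In a functional assay on A549 cells (Homo sapiens) for antiproliferative activity, read by sulforhodamine B assay, with a stated time of 48 h (on this read-out lower numbers stand for stronger inhibition of growth and higher numbers for weaker inhibition of growth), compound 2 gives 2760 nM and compound 1 gives 2190 nM. The change between them, (3-(hydroxycarbamoyl)propyl in place of hydroxycarbamoyl on a saturated chain carbon, four bonds along the chain from an oxygen on an aromatic ring), made a 1.3-fold lower number from compound 2 to compound 1 (0.10 log units; within the scatter). Compound 3 differs from compound 2 in its core. In this assay compound 3 gives only a limit, > 30000 nM. How the two cores differ is not broken down here. The limit is the limit of > 30000 nM in this assay, at which 1 of the 3 values shown sits. Compound 4 `CC(C)CCc1c(OCCCCCCCC(=O)NO)ccc2c1OC(=O)CC2` carries the same change on the core of compound 3: 3-(hydroxycarbamoyl)propyl in place of hydroxycarbamoyl on a saturated chain carbon, four bonds along the chain from an oxygen on an aromatic ring, with the place described in the same words as before. Because the measured instance of this change stayed within the scatter a 1.3-fold lower number from compound 2 to compound 1 (0.10 log units; within the scatter), compound 4 is expected to stay close to compound 3 in this assay, most likely again reported only as a limit. The estimated step is a step that the limit leaves unreadable from compound 3 to compound 4. Compound 4 is thus estimated at 35000 nM, between 10000 nM and 100000 nM.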

Compound 4, concentration for 50% growth inhibition: > 30000 nM
Compound 4 gave a limit, no number; the forecaster's own chance of this, stated with the estimate: 60%; the middle value does not contradict the limit.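

Compound 3 and compound 4 each give only a limit in this assay, so no step can be read between them: the limit of > 30000 nM in this assay, at which 2 of the 4 values shown sit.
As far as these compounds go, whether 3-(hydroxycarbamoyl)propyl in place of hydroxycarbamoyl changes growth inhibition on the core of compound 3 stays open.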